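Replacing 3,4,5-trimethoxyphenyl with furan-2-yl: what growth inhibition to expect

The source may report more compounds than this note shows. Statements on the series, on what has been measured and on what is new or still open speak of the compounds shown alone.

Measured so far in a functional assay on COLO 205 cells (Homo sapiens) for inhibition, read by sulforhodamine B assay, with a stated time of 48 h, tested at 50 uM; a lower number here means less inhibition of growth, a higher number more inhibition of growth at the concentration tested:
- compound 1 `COc1ccccc1/C=C/C(=O)/C=C/c1ccc(OCc2cn(CCCCCOc3cc(=O)oc4ccccc34)nn2)c(OC)c1`: 30%
- compound 2 `COc1cc(/C=C/C(=O)/C=C/c2ccccc2)ccc1OCc1cn(CCCCCOc2cc(=O)oc3ccccc23)nn1`: 22%
- compound 3 `COc1cc(/C=C/C(=O)/C=C/c2cc(OC)c(OC)c(OC)c2)ccc1OCc1cn(CCCCCOc2cc(=O)oc3ccccc23)nn1`: 51%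

Among these three, compound 3 gives the highest number, 51%, and its gaps to the other two lie beyond the usual scatter. The unmeasured compound 4 `COc1cc(/C=C/C(=O)/C=C/c2ccco2)ccc1OCc1cn(CCCCCOc2cc(=O)oc3ccccc23)nn1` keeps the rest of the structure and changes one group: furan-2-yl in place of 3,4,5-trimethoxyphenyl on a double-bonded chain carbon bound to a double-bonded chain carbon. In words, this is furan-2-yl in place of 3,4,5-trimethoxyphenyl on a double-bonded chain carbon bound to a double-bonded chain carbon.

Two measured steps changed the group at this same place. Putting 3,4,5-trimethoxyphenyl in place of phenyl gave a number 29 percentage points higher from compound 2 to compound 3 (beyond the scatter), and putting it in place of 2-methoxyphenyl gave a number 21 percentage points higher from compound 1 to compound 3 (beyond the scatter). The step between the two lower compounds is smaller: a number 8 percentage points lower from compound 1 to compound 2 (within the scatter). Furan-2-yl has not been measured at this place, so any forecast is uncertain. It carries no methoxy group, like the phenyl of compound 2 at 22%, so most of the gain seen with 3,4,5-trimethoxyphenyl is expected to be lost in this assay. The expected change is a modest fall: a number 24 percentage points lower from compound 3 to compound 4 (beyond the scatter). For compound 4 the estimated value is 27%, with an expected range from 13% to 42%.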

Compound 4, percent growth inhibition at one concentration: 33%
Beside the measured number, compound 4's estimate is 6 percentage points below it; measured number inside the range.
By their numbers in this assay, from the lowest: compounds 2, 1 and 4 (each within the scatter of the next, the first and the last beyond it); then compound 3.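

At this place, on a double-bonded chain carbon bound to a double-bonded chain carbon, the new result in this assay shows that 3,4,5-trimethoxyphenyl still stands apart: furan-2-yl gives a number 18 percentage points lower from compound 3 to compound 4 (beyond the scatter), and the steps from the other two compounds to compound 3 also lie beyond the scatter. The earlier compounds shown here left open whether a ring without methoxy groups would always fall as low as phenyl, but the furan-2-yl ring, which also has none, gives a number 11 percentage points higher from compound 2 to compound 4 (beyond the scatter), so the lack of a methoxy group does not by itself fix the number at the level of compound 2, while the comparison with 2-methoxyphenyl, a number 3 percentage points higher from compound 1 to compound 4 (within the scatter), shows no difference that can be told from the scatter. No evidence is available here that explains these differences.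

Still open, from the compounds shown here alone, is whether the oxygen of furan-2-yl matters, which a thiophene ring at this place could test, or whether a pyridine ring would behave the same way. A 3,4-dimethoxyphenyl or 4-methoxyphenyl group would help show how many methoxy groups are needed to reach the number of compound 3.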